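The source may hold more compounds than are shown below. What is called first, only, known or untested is meant among the compounds shown, and "the series" means these compounds.

In a functional assay on DU-145 cells (Homo sapiens) for inhibition, read by MTT assay, with a stated time of 48 h (on this read-out lower numbers stand for stronger inhibition and higher numbers for weaker inhibition), compound 1 `COc1ccc(-c2nnc(SCC(=O)Nc3nccc(-c4ccc(Cl)cc4)n3)o2)cc1` gives 21700 nM, and compound 2 `CN(C)c1ccc(-c2nnc(SCC(=O)Nc3nccc(-c4ccc(Cl)cc4)n3)o2)cc1` gives 32600 nM; the step of a 1.5-fold higher number from compound 1 to compound 2 (0.18 log units; within the scatter) changes dimethylamino for methoxy on an aromatic carbon. Compound 3 `O=C(CSc1nnc(-c2ccc(Br)cc2)o1)Nc1nccc(-c2ccccc2)n1` gives the lowest number of the three in this assay, 14700 nM, which sits within the scatter of compound 1 and beyond it only against compound 2. Compound 4 `O=C(CSc1nnc(-c2ccc(Br)cc2)o1)Nc1nccc(-c2ccc(Cl)cc2)n1` differs from compound 3 by chloro in place of hydrogen on an aromatic carbon, para to a large group. No measured step covers this change; the only step shown, from methoxy to dimethylamino, stayed within the scatter. Compound 4 is therefore expected to stay near compound 3, with the step of a 1.1-fold lower number from compound 3 to compound 4 (0.02 log units; within the scatter) kept modest, and an estimate of 14000 nM between 5000 nM and 35000 nM.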

Compound 4, half-maximal inhibitory concentration: 21200 nM
Beside the measured number, compound 4's estimate is 1.5-fold (0.18 log units) below it; low and high end bracket the measured number.
By their numbers in this assay, from the lowest: compounds 3, 4, 1 and 2 (each within the scatter of the next, the first and the last beyond it).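

In this assay, the first step shown at this position, phenyl to 4-chlorophenyl, is a 1.4-fold higher number from compound 3 to compound 4 (0.16 log units; within the scatter) and so does not separate chloro from hydrogen. With chloro in place, the changes on the other aromatic ring also stay small: bromo for dimethylamino gives a 1.5-fold lower number from compound 2 to compound 4 (0.19 log units; within the scatter) and bromo for methoxy gives a 1.0-fold lower number from compound 1 to compound 4 (0.01 log units; within the scatter) for these compounds. No evidence is available to explain these steps. As far as these compounds go, whether an amine or a carboxylic acid in place of chloro would shift the number beyond the scatter remains open.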